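Adding a methyl to the methoxy of compound 3

A few compounds are considered here, and "the series" means these few. Any claim that something is new, unique, unknown or untested is made for them only; others in the source may bear on it.

Measured so far:
compound 1, `CC(C)c1ccc2c(c1)[n+]([O-])c(NCCN1CCCCC1)n[n+]2[O-]`, gives 2700 nM in a functional assay on HT-29 cells (Homo sapiens) for cytotoxicity, with a stated time of 4 h; on this read-out lower numbers stand for stronger inhibition and higher numbers for weaker inhibition;
compound 2, `CC(C)(C)c1ccc2c(c1)[n+]([O-])c(NCCN1CCCCC1)n[n+]2[O-]`, gives 4000 nM;
compound 3, `COc1ccc2c(c1)[n+]([O-])c(NCCN(C)C)n[n+]2[O-]`, gives 7700 nM.

Compound 4, `CCOc1ccc2c(c1)[n+]([O-])c(NCCN(C)C)n[n+]2[O-]`, is not yet measured. It differs from compound 3 by methyl in place of hydrogen on a saturated chain carbon bound to an oxygen on an aromatic ring. The same kind of change, (methyl in place of hydrogen on a saturated chain carbon bound to an aromatic carbon and two saturated chain carbons), has already been made once, from compound 1 to compound 2, where it gave a 1.5-fold higher number from compound 1 to compound 2 (0.17 log units; within the scatter). The two places are not the same: in compound 1 the carbon that takes the methyl is bound to an aromatic carbon and two saturated chain carbons, whereas in compound 3 it is bound to an oxygen on an aromatic ring. The difference between the core of compound 1 and the core of compound 3 is not broken down here; their values simply show that compound 3 lies beyond the scatter from compound 1 and within it from compound 2.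

Given the small step seen in this assay from compound 1 to compound 2, compound 4 is expected to give a 1.2-fold higher number from compound 3 to compound 4 (0.09 log units; within the scatter), that is, a number near that of compound 3. The estimate for compound 4 is 9500 nM, between 4000 nM and 22000 nM.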

Compound 4, half-maximal inhibitory concentration: 2600 nM
Compound 4: middle estimate off by 3.7-fold (0.56 log units), on the high side; measured number below the stated range.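

In this assay, replacing methoxy with ethoxy gives a 3.0-fold lower number from compound 3 to compound 4 (0.47 log units; beyond the scatter). This added methyl therefore does not carry a fixed step from one core to another in this series, and the direction of the change is not the same on the two cores: the same change on two cores in this assay, a 1.5-fold higher number (0.17 log units; within the scatter) from compound 1 to compound 2 and a 3.0-fold lower number (0.47 log units; beyond the scatter) from compound 3 to compound 4, 4.4-fold (0.64 log units) apart, beyond the scatter of two such steps. The comparison does not show what sets the two steps apart, since the cores differ and the carbon taking the methyl is also of a different kind, bound to an aromatic carbon and two saturated chain carbons in compound 1 and to an oxygen on an aromatic ring in compound 3, and each case rests on a single pair.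

The compounds shown leave open whether the trend from methoxy to ethoxy goes on with propoxy or a longer chain on the oxygen, or how a hydroxyl in that place would compare. They also leave open what ethoxy in place of methoxy would give on the core of compound 1.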